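A few compounds are considered here, and "the series" means these few. Any claim that something is new, unique, unknown or untested is made for them only; others in the source may bear on it.

Compound 1 `COc1cccc(CNCCCNc2ccnc3cc(C4CCCCC4)ccc23)c1O` stands level with its two measured relatives in a physicochemical assay for solubility, with a stated time of 18 h, at pH 7.4 (on this read-out higher numbers stand for higher solubility and lower numbers for lower solubility), where compound 1 gives 4200 nM. Compound 2 `COc1ccc(F)cc1CNCCCNc1ccnc2cc(C3CCCCC3)ccc12` gives 4200 nM in this assay, and compound 3 `COc1ccc(F)cc1CNCCCNc1ccnc2cc(Cc3ccccc3)ccc12` gives 4200 nM. The step of no change at the digits printed from compound 1 to compound 2 (within the scatter) shows that exchanging the group on the saturated chain carbon bound to an amine nitrogen leaves the read-out where it was. The step of no change at the digits printed from compound 2 to compound 3 (within the scatter) shows the same for an exchange on an aromatic carbon of the shared core, with benzyl in place of cyclohexyl.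

Compound 4 `COc1cccc(CNCCCNc2ccnc3cc(CCc4ccccc4)ccc23)c1O` differs from compound 1 as follows: phenethyl in place of cyclohexyl on an aromatic carbon. Among the measured compounds shown here, the measured step that bears on it most directly is the one from compound 2 to compound 3, where cyclohexyl also left an aromatic carbon and the read-out did not move beyond the scatter. The step from compound 1 to compound 2 adds that the group on the chain carbon, which compound 4 shares with compound 1, made no difference either. On this basis no step beyond the scatter is expected in this assay for compound 4, the expected step being no change at the digits printed from compound 1 to compound 4 (within the scatter). Compound 4 is therefore estimated to give 4200 nM, with an expected range from 2100 nM to 8400 nM.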

Compound 4, solubility: 4200 nM
Compound 4: the middle estimate sits on the measured number at the digits printed, and the stated range covers the measured number.
By their numbers in this assay, from the lowest: compounds 1, 2, 3 and 4 (each within the scatter of the next).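

In this assay, phenethyl on this aromatic carbon gives no change at the digits printed from compound 1 to compound 4 (within the scatter), so an exchange at this position again leaves the read-out in place, this time with the 2-hydroxy-3-methoxyphenyl group of compound 1 on the chain rather than the 5-fluoro-2-methoxyphenyl group. The entering group has 8 heavy atoms against 6 for cyclohexyl and brings an aromatic ring in place of a non-aromatic one, and neither difference appears in the read-out for this pair. No measurement shown here gives a reason for this flat result.

Cyclohexyl and phenethyl are both all-carbon groups with no net charge, so the effect of an amine or a carboxylic acid at this position remains open. Also open, going by these compounds, is whether any group here, or a longer chain between the two amine nitrogens, would move the read-out beyond the scatter.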